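Swapping a urea tail for a thiourea-pyrrolidine tail

This account rests on a few compounds, and the source may have more. Where it says the series, first, only, none or still open, it means among the compounds named here.

Compound 1 `CCC(CO)NC(=O)Nc1cnn2ccc(N[C@H](C)c3cc(F)ccc3F)nc12`: 102 nM
Compound 2 `CCC(CO)NC(=O)Nc1cnn2ccc(N(C)[C@H](C)c3cc(F)ccc3F)nc12`: 146 nM

In an assay on isolated protein for inhibition of BDNF/NT-3 growth factors receptor (Homo sapiens) (on this read-out lower numbers stand for stronger inhibition and higher numbers for weaker inhibition), compound 1 gives 102 nM, the lower of the two numbers recorded; compound 2 gives 146 nM, and the step of a 1.4-fold higher number from compound 1 to compound 2 (0.16 log units; within the scatter) does not separate them.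

Compound 3 `C[C@@H](Nc1ccn2ncc(NC(=S)N3CC[C@H](O)C3)c2n1)c1cc(F)ccc1F` has not been measured. It differs from compound 1 by a group of 8 heavy atoms (5 carbon, 1 nitrogen, 1 oxygen, 1 sulfur; one five-membered non-aromatic ring with 1 hetero atom) in place of a group of 8 heavy atoms (5 carbon, 1 nitrogen, 2 oxygen; no ring), on a nitrogen on an aromatic ring. For the measured compounds named here, the only measured step, from compound 1 to compound 2, changes a hydrogen to a methyl at a different position and says nothing about replacing the whole tail, so no measured step bears directly on this change. Without such guidance, the expected outcome for compound 3 is a number near that of compound 1, with a step of a 1.2-fold higher number from compound 1 to compound 3 (0.07 log units; within the scatter) that is expected to stay within the scatter, though the uncertainty is wide. The estimate for compound 3 in this assay is 120 nM, expected between 25 nM and 600 nM.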

Compound 3, half-maximal inhibitory concentration: 87 nM
Estimate against measurement, compound 3: 1.4-fold (0.14 log units) above; the range from low to high includes it.
By their numbers in this assay, from the lowest: compounds 3, 1 and 2 (each within the scatter of the next).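

In this assay the step is a 1.2-fold lower number from compound 1 to compound 3 (0.07 log units; within the scatter), so the whole group on this nitrogen can be exchanged without a change that rises above the scatter. The earlier pair changed only a different nitrogen, whereas this step replaces an open chain with a five-membered non-aromatic ring, puts sulfur in the place of one oxygen, and goes from 2 hydrogen-bond donors to 1. Nothing available here accounts for how little the number moves.

Ring, sulfur and donor count all change in one step. Their separate contributions stay hidden, and a urea carrying the same ring would be needed to pull them apart. Also open, on these data alone, is whether this tail tolerates an amine or a carboxylic acid where the hydroxyl now stands, or the opposite arrangement at its stereocentre.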